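The source may hold more compounds than are shown below. What is called first, only, known or untested is meant among the compounds shown, and "the series" means these compounds.

Values in a functional assay on MCF7 cells (Homo sapiens) for cytotoxicity, read by MTT assay, with a stated time of 48 h (on this read-out lower numbers stand for stronger inhibition of growth and higher numbers for weaker inhibition of growth), for the series so far:
compound 1 `Cc1nc2cc(Cl)c(Cl)cc2n1[C@@H]1O[C@H](CO)[C@@H](O)[C@H]1O` gives "not determined" (no result reported) with no number to compare
compound 2 `CCn1c(C(F)(F)F)nc2cc(Cl)c(Cl)cc21` gives 72900 nM as its growth-inhibition value
compound 3 `FC(F)(F)c1cccc(Cn2c(C(F)(F)F)nc3cc(Cl)c(Cl)cc32)c1` gives 68000 nM as its growth-inhibition value

Within the data shown here, compound 2 has no clear rank among the measured compounds: its only numerical neighbour, compound 3, lies within the scatter of it. Next is compound 4 `FC(F)(F)c1nc2cc(Cl)c(Cl)cc2n1C1CCCC1`, with cyclopentyl in place of ethyl on an aromatic nitrogen of compound 2 (cyclopentyl in place of ethyl on an aromatic nitrogen). Among the measured compounds shown here, no measured step shows the effect of this change. With compound 3 at 68000 nM and compound 2 at 72900 nM within the scatter of each other, no step beyond the scatter is expected in this assay for compound 4. The expected step (a 1.3-fold lower number from compound 2 to compound 4 (0.12 log units; within the scatter)) leans slightly towards stronger inhibition. For compound 4 the estimated value is 55000 nM with an expected range from 22000 nM to 110000 nM in this read-out.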

Compound 4, concentration for 50% growth inhibition: 21000 nM
Beside the measured number, compound 4's estimate is 2.6-fold (0.42 log units) above it, outside the stated range (below it).
By their numbers in this assay, from the lowest: compound 4; then compounds 3 and 2 (each within the scatter of the next).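

In this assay, the series shows its first step beyond the scatter: cyclopentyl in place of ethyl on the aromatic nitrogen gives a 3.5-fold lower number from compound 2 to compound 4 (0.54 log units; beyond the scatter), a modest gain. This position, next to the ring atom that bears a trifluoromethyl group, therefore responds to replacing the two-carbon chain with a five-membered carbon ring. Nothing measured here accounts for the step. Open, going by these compounds, is whether the ring itself is needed, or whether a longer chain such as n-pentyl would do the same. Also open, on these data alone, is how a cyclohexyl ring, or an amine on the cyclopentyl ring, would read.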